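Swapping the amide heteroaryl of compound 2 for compound 3

This account rests on a few compounds, and the source may have more. Where it says the series, first, only, none or still open, it means among the compounds named here.

Compound 1 `O=C(NCc1ccc(S(=O)(=O)N2CCCCC2)cc1)c1cnc2nccn2c1` and compound 2 `O=C(NCc1ccc(S(=O)(=O)c2cccc(C(F)(F)F)c2)cc1)c1cnc2nccn2c1` share an amide core and differ only at the sulfonyl sulfur. In an ADME assay on microsomes from liver (Homo sapiens) for metabolic stability, read by LC-MS, with a stated time of 30 min, tested at 1 uM (a higher number here means that more of the compound is left, a lower number that less of the compound is left), compound 1 gives 64%, while compound 2 gives 41%, the lower of the two numbers; the step of a number 23 percentage points lower from compound 1 to compound 2 (beyond the scatter) lies beyond the scatter. Compound 3 `O=C(NCc1ccc(S(=O)(=O)c2cccc(C(F)(F)F)c2)cc1)c1ccc2nccn2c1` keeps the sulfonyl part of compound 2 unchanged and alters the other end: a group of 9 heavy atoms (7 carbon, 2 nitrogen; one five-membered aromatic ring with 2 hetero atoms, one six-membered aromatic ring with 1 hetero atom) in place of a group of 9 heavy atoms (6 carbon, 3 nitrogen; one five-membered aromatic ring with 2 hetero atoms, one six-membered aromatic ring with 2 hetero atoms), on a carbonyl carbon. No measured step bears on this part of the molecule, since the only step shown concerns the sulfonyl substituent, so the data give no guide to the direction of the change. Compound 3 is therefore expected to stay close to compound 2, with a step of a number 6 percentage points lower from compound 2 to compound 3 (within the scatter) that may well fall within the scatter. The estimate for compound 3 in this assay is 35%, within a range of 15% to 55%.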

Compound 3, percent of the compound remaining: 26%
The estimate for compound 3 lay 9 percentage points above the measured number, and the stated range covers the measured number.
By their numbers in this assay, from the lowest: compound 3; then compound 2; then compound 1.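

In this assay, the group on the carbonyl carbon proves to matter as well (a number 15 percentage points lower from compound 2 to compound 3 (beyond the scatter)): the group of 7 carbon and 2 nitrogen atoms leaves less of the compound than the group of 6 carbon and 3 nitrogen atoms. The earlier compounds showed a change only at the sulfonyl sulfur (a number 23 percentage points lower from compound 1 to compound 2 (beyond the scatter)), so both ends of the molecule now register in this read-out, each listed step giving a lower number. Nothing measured here accounts for the step at the carbonyl carbon.

This change is shown only with 3-(trifluoromethyl)phenyl on the sulfonyl sulfur, so whether it gives a similar step with the piperidin-1-yl of compound 1 stays open. Also open, as far as these compounds go, is how morpholin-4-yl on the sulfonyl sulfur, or a plain phenyl ring on the carbonyl carbon, would read in this assay.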